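The source may hold more compounds than are shown below. What is called first, only, known or untested is meant among the compounds shown, and "the series" means these compounds.

In a functional assay on DU-145 cells (Homo sapiens) for cytotoxicity, read by CCK-8 assay and cell counting, with a stated time of 2 days (on this read-out higher numbers stand for weaker inhibition and lower numbers for stronger inhibition), compound 2 `Oc1cccc(-c2cc(-c3ccccc3)nc(-c3ccc(Cl)cc3)c2)c1` gives 11200 nM, the highest of the two numbers recorded, while compound 1 `Oc1cccc(-c2cc(-c3cccs3)nc(-c3ccccc3Cl)c2)c1` gives 1700 nM, a lower number beyond the scatter. Compound 3 `Oc1cccc(-c2cc(-c3ccccc3)nc(-c3ccccc3Cl)c2)c1` has not been measured in this assay. It differs from compound 2 by 2-chlorophenyl in place of 4-chlorophenyl on an aromatic carbon. Compound 3 shares this 2-chlorophenyl group with compound 1, whose value of 1700 nM is the lower of the two. On that basis a step toward a lower number is expected from compound 2 to compound 3, estimated at a 2.5-fold lower number from compound 2 to compound 3 (0.40 log units; beyond the scatter). For compound 3 the estimate in this assay is 4500 nM, with a range from 1500 nM to 13000 nM.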

Compound 3, half-maximal inhibitory concentration: 1480 nM
The estimate for compound 3 lay 3.0-fold (0.48 log units) above the measured number; measured number below the stated range.
By their numbers in this assay, from the lowest: compounds 3 and 1 (each within the scatter of the next); then compound 2.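

In this assay, 2-chlorophenyl in place of 4-chlorophenyl gives a 7.6-fold lower number from compound 2 to compound 3 (0.88 log units; beyond the scatter), so with the same atoms joined differently, the place of the chlorine on this ring makes a difference beyond the scatter. Phenyl in place of thiophen-2-yl gives a 1.1-fold lower number from compound 1 to compound 3 (0.06 log units; within the scatter), so these two groups are not told apart while 2-chlorophenyl is present. Nothing available explains why the place of the chlorine matters. The compounds shown leave open how 3-chlorophenyl, or an amine or a carboxylic acid on this ring, would read. On these data alone, whether phenyl and thiophen-2-yl also match alongside 4-chlorophenyl stays open too.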